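The compounds below may be only part of what the source reports. "The series", "measured", "known", "first", "only" and "open" are said of these compounds alone.

Compound 1, `COc1cc(Cc2nc3c(N)ncnc3n2CC2CC2)cc(OC)c1OC`, is the weakest of the three compounds measured here: in a functional assay on MCF7 cells (Homo sapiens) for antiproliferative activity (on this read-out lower numbers stand for stronger inhibition and higher numbers for weaker inhibition), compound 1 gives 75900 nM. Compound 3, `CCCCn1c(Cc2cc(OC)c(OC)c(OC)c2Cl)nc2c(N)ncnc21`, gives 19100 nM in this assay, and compound 2, `COc1cc(Cc2nc3c(N)nc(F)nc3n2CCOC(C)C)c(Cl)c(OC)c1OC`, gives 5370 nM; both gaps to compound 1 lie beyond the usual scatter, so compound 1 stands clearly apart as the least active of the three.

Compound 4, `COc1cc(Cc2nc3c(N)ncnc3n2C)cc(OC)c1OC`, has not yet been measured. It differs from compound 1 in one place: hydrogen in place of cyclopropyl on a saturated chain carbon bound to an aromatic nitrogen. Read one bond further out, the change is cyclopropylmethyl to methyl, so the chain on the aromatic nitrogen becomes shorter. For the measured compounds named here, no pair of measured compounds differs in just this one place, so there is no measured step to lean on; compound 2 and compound 3 each differ from compound 1 in more than one place, and their values show only that those larger changes came with lower numbers.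

For this single change a small step is expected, a 1.4-fold higher number from compound 1 to compound 4 (0.16 log units; within the scatter), with the number for compound 4 expected to come out somewhat higher than that of compound 1 or not separable from it within the scatter. Compound 4 is therefore estimated at 110000 nM, with a likely range from 35000 nM to 350000 nM.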

Compound 4, half-maximal inhibitory concentration: 70800 nM
Compound 4: middle estimate off by 1.6-fold (0.19 log units), on the high side; measured number inside the range.
By their numbers in this assay, from the lowest: compound 2; then compound 3; then compounds 4 and 1 (each within the scatter of the next).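

For the compounds shown here, this is the first measured step at this position, and it separates nothing: in this assay the change from cyclopropylmethyl to methyl on the aromatic nitrogen gives a result within the scatter (a 1.1-fold lower number from compound 1 to compound 4 (0.03 log units; within the scatter)). On this core, then, the three carbons and the three-membered ring of the cyclopropyl group can be replaced by a single hydrogen with no readable effect on the number, and compound 4 gives 70800 nM. Going by these compounds alone, the result covers only this one pair, so it says that these two groups read alike here, not that every group at this position would. Nothing available explains why the two compounds read alike.

The pair leaves open whether a group of a different kind on this nitrogen, such as a chain ending in an amine or a carboxylic acid, would move the number beyond the scatter. It also leaves open how much of the lower numbers of compound 2 and compound 3 comes from their chains on the nitrogen, since each differs from compound 1 in more than one place.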